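The compounds below may be only part of what the source reports. "The series", "measured", "known", "first", "only" and "open" are said of these compounds alone.

Measured in a functional assay on DU-145 cells (Homo sapiens) for inhibition, read by trypan blue exclusion, with a stated time of 96 h; a lower number here means a stronger inhibitor of growth, a higher number a weaker inhibitor of growth:
- Compound 1 `Cc1ccc(S(=O)(=O)/C(=C/c2ccc(C)s2)C(=O)c2ccc(Cl)cc2)cc1`: 50000 nM
- Compound 2 `Cc1ccc(CS(=O)(=O)/C(=C/c2ccc(C)s2)C(=O)c2ccc(Cl)cc2)cc1`: 25000 nM

Compound 2 holds the lower of these two numbers, but the gap is small: a 2.0-fold lower number from compound 1 to compound 2 (0.30 log units; within the scatter). The two compounds therefore cannot be told apart in this assay. Compound 3 `Cc1ccc(/C=C(\C(=O)c2ccc(Cl)cc2)S(=O)(=O)Cc2ccc(Cl)cc2)s1` turns 4-methylbenzyl into 4-chlorobenzyl, with chloro in place of methyl on an aromatic carbon. For the measured compounds named here, no measured step makes this change. The only one available, a 2.0-fold lower number from compound 1 to compound 2 (0.30 log units; within the scatter), concerns a different change and stays within the scatter, so no shift beyond the scatter is expected. The expected result is a 1.3-fold lower number from compound 2 to compound 3 (0.10 log units; within the scatter). For compound 3 the estimated value is 20000 nM, with an expected range of 8000 nM to 50000 nM.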

Compound 3, concentration for 50% growth inhibition: 1000 nM
The estimate for compound 3 lay 20-fold (1.30 log units) above the measured number; measured number outside the range, below it.
By their numbers in this assay, from the lowest: compound 3; then compounds 2 and 1 (each within the scatter of the next).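

Unlike the earlier step, which stayed within the scatter, the exchange of 4-methylbenzyl for 4-chlorobenzyl gives a 25-fold lower number from compound 2 to compound 3 (1.40 log units; beyond the scatter) in this assay, so this single substituent has a large influence on growth inhibition. The 4-chlorobenzyl group also gives a 50-fold lower number from compound 1 to compound 3 (1.70 log units; beyond the scatter) when set against the 4-methylphenyl group. No available evidence explains this jump. Going by these compounds, whether fluoro, bromo, methoxy or an amine at this place would match chloro remains open. So does whether chloro would have the same effect on the 4-methylphenyl group of compound 1.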